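Chloro in Place of Fluoro: Compound 3 to Compound 4

A few compounds are considered here, and "the series" means these few. Any claim that something is new, unique, unknown or untested is made for them only; others in the source may bear on it.

Going by the values given here, compound 3 `CC/C(=C(/c1ccc(/C=C/C(=O)O)cc1)c1ccc2[nH]ncc2c1F)c1ccccc1` gives 3 nM in a functional assay on MCF7 cells (Homo sapiens) for cytotoxicity, read by CellTiter-Glo, with a stated time of 5 days (a higher number here means a weaker inhibitor, a lower number a stronger inhibitor), the lowest of the three numbers measured so far. Compound 2 `CC/C(=C(/c1ccc(/C=C/C(=O)O)cc1)c1ccc2[nH]nc(F)c2c1)c1ccccc1` gives 5 nM in this assay, and the step of a 1.7-fold lower number from compound 2 to compound 3 (0.22 log units; within the scatter) lies within the scatter, so these two compounds cannot be ordered against each other. Compound 1 `CC/C(=C(/c1ccc(/C=C/C(=O)O)cc1)c1ccc2[nH]ncc2n1)c1ccccc1` gives 33 nM in this assay; the steps of an 11-fold lower number from compound 1 to compound 3 (1.04 log units; beyond the scatter) and a 6.6-fold lower number from compound 1 to compound 2 (0.82 log units; beyond the scatter) are both beyond the scatter. Compound 4 `CC/C(=C(/c1ccc(/C=C/C(=O)O)cc1)c1ccc2[nH]ncc2c1Cl)c1ccccc1` differs from compound 3 by chloro in place of fluoro on an aromatic carbon. Among the compounds with values here, no measured step swaps one halogen for another. Within the data shown here, the only step that touches the fluoro, the one from compound 2 to compound 3, stayed within the scatter, while the two larger steps from compound 1 replaced a whole ring system and carry no information about a change this small. The expected step of a 1.2-fold higher number from compound 3 to compound 4 (0.07 log units; within the scatter) is therefore none beyond the scatter. Compound 4 is estimated at 3.5 nM in this assay, with a range from 1.2 nM to 10 nM.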

Compound 4, half-maximal inhibitory concentration: 1.6 nM
For compound 4 the middle estimate is 2.2-fold (0.34 log units) above the measured one, within the range that was stated.
By their numbers in this assay, from the lowest: compounds 4, 3 and 2 (each within the scatter of the next, the first and the last beyond it); then compound 1.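

Going by these compounds alone, the first exchange of one halogen for another on this aromatic carbon gives a 1.9-fold lower number from compound 3 to compound 4 (0.27 log units; within the scatter) and so, in this assay, chloro and fluoro cannot be told apart at this place. The change of group does show something the fluoro compounds did not: a 3.1-fold lower number from compound 2 to compound 4 (0.49 log units; beyond the scatter) separates 4-chloro-1H-indazol-5-yl from 3-fluoro-1H-indazol-5-yl, which 4-fluoro-1H-indazol-5-yl did not do, and a 21-fold lower number from compound 1 to compound 4 (1.31 log units; beyond the scatter) is the widest step in the set. Nothing measured on these compounds accounts for the numbers.

The compounds shown leave open whether a bromo or a methyl group on this same carbon would stay level with chloro and fluoro. They also leave open whether the 4-chloro-1H-indazol-5-yl group would hold its standing with an amide in place of the carboxylic acid.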